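A few compounds are considered here, and "the series" means these few. Any claim that something is new, unique, unknown or untested is made for them only; others in the source may bear on it.

Compound 3 `COc1ccc(/C=C\C(=O)O)c(OCc2cn(-c3ccccc3I)nn2)c1CC=C(C)C` is one of a small set of cinnamic acid derivatives tested in a functional assay on A-431 cells (Homo sapiens) for cytotoxicity, read by MTT assay, with a stated time of 24 h; on this read-out higher numbers stand for weaker inhibition and lower numbers for stronger inhibition. In this assay compound 3 gives 32700 nM, the highest of the two numbers available. Its nearest neighbour, compound 1 `COc1ccc(/C=C\C(=O)O)c(OCc2cn(-c3cccc(C#N)c3)nn2)c1CC=C(C)C`, gives 22900 nM; the step of a 1.4-fold higher number from compound 1 to compound 3 (0.15 log units; within the scatter) lies within the scatter. A third member, compound 2 `COc1ccc(-n2cc(COc3c(/C=C\C(=O)O)ccc(OC)c3CC=C(C)C)nn2)cc1`, stands at "not determined" (no result reported) in this assay, so no number is available for it.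

Compound 4 `COc1ccc(/C=C\C(=O)O)c(OCc2cn(-c3cccc([N+](=O)[O-])c3)nn2)c1CC=C(C)C` differs from compound 3 in a single place: 3-nitrophenyl in place of 2-iodophenyl on an aromatic nitrogen. Within the data shown here, the only measured step that bears on this position, a 1.4-fold higher number from compound 1 to compound 3 (0.15 log units; within the scatter), exchanged one substituted phenyl for another on the same aromatic nitrogen without moving the number beyond the scatter. Nothing in the set separates the effect of a nitro group from that of a nitrile or an iodine at this position. On that basis a step of about a 1.2-fold lower number from compound 3 to compound 4 (0.07 log units; within the scatter) is expected, that is, no change beyond the scatter. Compound 4 is therefore estimated at 28000 nM in this assay, with a range from 12000 nM to 65000 nM.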

Compound 4, half-maximal inhibitory concentration: 18400 nM
For compound 4 the middle estimate is 1.5-fold (0.18 log units) above the measured one; low and high end bracket the measured number.
By their numbers in this assay, from the lowest: compounds 4, 1 and 3 (each within the scatter of the next).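

In this assay the nitro-bearing ring behaves like the two substituted phenyl groups before it: a 1.8-fold lower number from compound 3 to compound 4 (0.25 log units; within the scatter) and a 1.2-fold lower number from compound 1 to compound 4 (0.10 log units; within the scatter) both stay within the scatter. Three different substituted phenyl groups on this aromatic nitrogen therefore give numbers that cannot be told apart, and the exchange of nitro for cyano on an aromatic carbon adds a second kind of change that leaves the number within the scatter. No measurement offered here accounts for this lack of separation.

All three numbers come from compounds with a substituted phenyl on this nitrogen. As far as these compounds go, whether an unsubstituted phenyl, a benzyl group, or a phenyl carrying an amine or a carboxylic acid would give a number outside this band remains open.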